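Swapping a Carbamate for an Amine on a Shared Core

The compounds below may be only part of what the source reports. "The series", "measured", "known", "first", "only" and "open" are said of these compounds alone.

Of the compounds shown here, three built on one shared core have been measured in an assay for inhibition of 15-hydroxyprostaglandin dehydrogenase [NAD(+)] (Homo sapiens), read by fluorescence, with a stated time of 15 min, in the presence of a further agent that is not named here; on this read-out higher numbers stand for weaker inhibition and lower numbers for stronger inhibition. Compound 1 `Nc1c([S+]([O-])CCCF)sc2nc(-c3cccs3)cc(-c3ccccc3)c12` gives 6.1 nM. Compound 2 `CCCC[S+]([O-])c1sc2nc(-c3nccs3)cc(-c3ccc(COC(=O)NCC)cc3)c2c1N` gives 3.4 nM. Compound 3 `CCCC[S+]([O-])c1sc2nc(-c3nccn3C)nc(-c3ccccc3)c2c1N` gives 3.7 nM. Compound 2 has the lowest of the three numbers, yet its gap to compound 3 and its gap to compound 1 both lie within the usual scatter of repeated measurements, so none of the three can be ranked against the others.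

Compound 4 `CCCC[S+]([O-])c1sc2nc(-c3nccs3)cc(-c3ccc(CN)cc3)c2c1N` has not yet been measured. It differs from compound 2 in one place: amino in place of (ethylcarbamoyl)oxy on a saturated chain carbon bound to an aromatic carbon. Among the compounds with values here, no pair of measured compounds differs by a change of this kind, so no measured step shows what it does. A change that removes most of a side group, as this one does, may move the number beyond the scatter, but the direction cannot be read from the measured compounds. A modest weakening is expected, giving an estimated step of a 2.4-fold higher number from compound 2 to compound 4 (0.37 log units; beyond the scatter) in this assay. Compound 4 is therefore expected to give about 8 nM, with an estimated range from 2 nM to 30 nM.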

Compound 4, half-maximal inhibitory concentration: 11.5 nM
Compound 4: middle estimate off by 1.4-fold (0.16 log units), on the low side; measured number inside the range.
By their numbers in this assay, from the lowest: compounds 2, 3, 1 and 4 (each within the scatter of the next, the first and the last beyond it).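

In this assay, within the data shown here, cutting (ethylcarbamoyl)oxy back to amino on this saturated chain carbon bound to an aromatic carbon gives a 3.4-fold higher number from compound 2 to compound 4 (0.53 log units; beyond the scatter) and is the only measured step at this position, one that lies beyond the scatter. The number therefore responds to what sits at this place, and the larger group gives the lower number, though the step is modest: with most of the side group gone, compound 4 still gives 11.5 nM as a value in the nanomolar range. Nothing available explains this step.

A single step cannot show which part of the (ethylcarbamoyl)oxy group accounts for the difference. As far as these compounds go, a hydroxyl group, an acetamide or a carboxylic acid at the same place would help separate the contributions of its parts, and whether the same change behaves alike on other compounds remains open.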